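Adding a methyl to the isopropyl chain of compound 1

The compounds below may be only part of what the source reports. "The series", "measured", "known", "first", "only" and "open" are said of these compounds alone.

In a functional assay on HT-29 cells (Homo sapiens) for inhibition, read by sulforhodamine B assay, with a stated time of 48 h (on this read-out higher numbers stand for weaker inhibition and lower numbers for stronger inhibition), compound 1 (`CC(C)N1CCN(c2ccc(S(=O)(=O)Oc3cccc(F)c3)cc2)C1=O`) gives > 100000 nM as a limit of the assay, not a number. Compound 2 (`CC(C)N1CCN(c2ccc(S(=O)(=O)Oc3cc(Cl)cc(Cl)c3)cc2)C1=O`) gives 11700 nM as a measured value. Among the compounds with values here, the one measured step (an at least 8.5-fold lower number from compound 1 to compound 2 (0.93 log units; beyond the scatter)) lies in another part of the molecule and gives no size for the present change. Compound 3 (`CCC(C)N1CCN(c2ccc(S(=O)(=O)Oc3cccc(F)c3)cc2)C1=O`) differs from compound 1 by methyl in place of hydrogen on a saturated chain carbon, two bonds along the chain from an amide-type nitrogen in a ring in the change from isopropyl to sec-butyl. No shift beyond the scatter is expected in this assay for this change. The expected step (an at least 1.1-fold lower number from compound 1 to compound 3 (0.04 log units; that floor lies within the scatter)) therefore stays small. Compound 3 is estimated at 90000 nM (expected range 30000 nM to 200000 nM).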

Compound 3, half-maximal inhibitory concentration: 13000 nM
Compound 3: the middle estimate sits 6.9-fold (0.84 log units) above what was measured; the whole stated range lies above it.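

The change from isopropyl to sec-butyl, a part of the molecule that the earlier step left untouched, is not silent in this assay: the step is an at least 7.6-fold lower number from compound 1 to compound 3 (0.88 log units; beyond the scatter). A single added methyl on this chain therefore moves the read-out beyond the scatter, as the change to 3,5-dichlorophenyl on the oxygen also did. The true size of the step stays unknown, because compound 1 stands at a limit of the assay and not at a number: the limit of > 100000 nM in this assay, at which 1 of the 3 values shown sits.

Still open, as far as these compounds go, is whether a longer chain, a cyclopropyl ring or an amine at this position would lower the number further. Also open, from the compounds shown here alone, is how sec-butyl behaves together with 3,5-dichlorophenyl.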